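A few compounds are considered here, and "the series" means these few. Any claim that something is new, unique, unknown or untested is made for them only; others in the source may bear on it.

Measured so far:
compound 1, `CCCCCCCC/C=C\CCCCCCCC(=O)N[C@H]1[C@@H](OCCCCCCCC)O[C@H](CO)[C@@H](O)[C@@H]1O`, 12 uM
compound 2, `CCCCC(=O)N[C@H]1[C@@H](OCCc2ccccc2)O[C@H](COCC(CO)(CO)COS(=O)(=O)O)[C@@H](O)[C@@H]1O`, 8.6 uM

In a functional assay on C6 cells (Rattus norvegicus), read by thymidine incorporation (a lower number here means a stronger inhibitor, a higher number a weaker inhibitor), compound 2 gives 8.6 uM and compound 1 gives 12 uM; these two numbers lie within the scatter of each other, so neither stands apart from the other. Compound 3, `CCCCC(=O)N[C@H]1[C@@H](OCCc2ccccc2)O[C@H](COCC(O)CO)[C@@H](O)[C@@H]1O`, is not yet measured. It differs from compound 2 in one place: 1,2-dihydroxyethyl in place of 2-hydroxy-1-(hydroxymethyl)-1-((sulfooxy)methyl)ethyl on a saturated chain carbon bound to an oxygen on a saturated carbon. Within the data shown here, no measured pair shows a change of this kind, so the size of the step rests on no prior data. The expected step of a 1.4-fold higher number from compound 2 to compound 3 (0.14 log units; within the scatter) is none beyond the scatter, at most a mild weakening. For compound 3 the estimate is 12 uM, with a range from 4 uM to 40 uM.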

Compound 3, concentration for 50% inhibition: > 50 uM
Compound 3 gave a limit, no number; the forecaster's own chance of this, stated with the estimate: 10%; middle value at least 4.1-fold (0.61 log units) away from the limit.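

In this assay, 1,2-dihydroxyethyl in place of 2-hydroxy-1-(hydroxymethyl)-1-((sulfooxy)methyl)ethyl gives an at least 5.8-fold higher number from compound 2 to compound 3 (0.76 log units; beyond the scatter), so this position is sensitive to this change. Compound 3 carries a limit, not a number, so only a minimum size of the step can be read: the limit of > 50 uM in this assay, at which 1 of the 3 values shown sits.

The change removes the sulfooxy group and the hydroxymethyl branches together, so their contributions cannot be separated. As far as these compounds go, whether a carboxylic acid or a phosphate group in place of the sulfooxy group would keep the inhibition remains open.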